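Trimming a fused lactam on a shared core: predicted clearance

This account rests on a few compounds, and the source may have more. Where it says the series, first, only, none or still open, it means among the compounds named here.

Measured compounds:
Compound 1, `O=C1c2ccccc2CN1c1cnc(NCc2c(F)ccc3c2CCO3)n2cnnc12`, 13 mL.min-1.g-1
Compound 2, `Cc1ncc(-c2cnc(NCc3c(F)ccc4c3CCO4)c3cn[nH]c(=O)c23)n1C`, 10 mL.min-1.g-1
Compound 3, `Cc1ncccc1-c1cnc(NCc2c(F)ccc3c2CCO3)c2cn[nH]c(=O)c12`, 41 mL.min-1.g-1

In an ADME assay on microsomes from liver (Homo sapiens) for metabolic stability, read by LC-MS, using NADPH, with stated times of 5 min and 30 min, tested at 1 uM (a lower number here means slower removal, a higher number faster removal of the compound), compound 1 stands second highest of the three numbers. Its nearest neighbour is compound 2, which is within the scatter of compound 1, while compound 3 lies furthest away, beyond the scatter on the higher side. Among the compounds with values here, the only step between measured compounds that differ in one place is a 4.1-fold higher number from compound 2 to compound 3 (0.61 log units; beyond the scatter); it concerns a heteroaryl swap on a different core and does not bear directly on the change at hand.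

Compound 4 is `C[C@H]1CC(=O)N(c2cnc(NCc3c(F)ccc4c3CCO4)n3cnnc23)C1`. Relative to compound 1 the change is a group of 7 heavy atoms (5 carbon, 1 nitrogen, 1 oxygen; one five-membered non-aromatic ring with 1 hetero atom) in place of a group of 10 heavy atoms (8 carbon, 1 nitrogen, 1 oxygen; one five-membered non-aromatic ring with 1 hetero atom, one six-membered aromatic ring of carbon only), on an aromatic carbon. Within the data shown here, no measured pair shows this kind of replacement, so the expectation rests on compound 1 alone. Among the measured compounds shown here, the group that enters is smaller than the one that leaves, and nothing among the measured compounds argues for a large move in either direction. The number for compound 4 in this assay is therefore expected to stay near that of compound 1, with a step of a 1.3-fold lower number from compound 1 to compound 4 (0.11 log units; within the scatter) that lies within the scatter. The estimate for compound 4 is 10 mL.min-1.g-1, between 5 mL.min-1.g-1 and 22 mL.min-1.g-1.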

Compound 4, intrinsic clearance in microsomes: < 3 mL.min-1.g-1
Compound 4 ended at the assay's limit; the forecaster's own chance of this, stated with the estimate: 10%; at least 3.3-fold (0.52 log units) between middle value and limit.
By their numbers in this assay, from the lowest: compounds 2 and 1 (each within the scatter of the next); then compound 3. At a limit, below all of these: compound 4.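

At this position on the shared core, an aromatic carbon, the swap to 4-methyl-2-oxopyrrolidin-1-yl gives an at least 4.3-fold lower number from compound 1 to compound 4 (0.63 log units; beyond the scatter) in this assay. Within the data shown here, the earlier compounds offered only a heteroaryl swap on a different core, so this is the first sign that the number on this core answers to the group at this place, even though the counts of hydrogen-bond donors and acceptors and the net charge stay the same. The value of compound 4, < 3 mL.min-1.g-1, is a limit of the assay and not a number, so the step gives a minimum size and no more: the limit of < 3 mL.min-1.g-1 in this assay, at which 1 of the 4 values shown sits.

The change removes the six-membered aromatic ring of carbon only and brings in a methyl group on a defined stereocentre, and the compounds shown do not separate these two parts. On these data alone, how the plain 2-oxopyrrolidin-1-yl group without the methyl, the opposite configuration at that stereocentre, or an open-chain acetamide at this carbon would read in this assay remains open.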